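Dropping the Methoxy Group: What to Expect for Compound 3

The source may hold more compounds than are shown below. What is called first, only, known or untested is meant among the compounds shown, and "the series" means these compounds.

Measured so far:
compound 1, `O=C(CSc1nc2ccccc2[nH]1)c1ccc(O)cc1`: 19200 nM
compound 2, `COc1ccccc1C(=O)CSc1nc2ccccc2[nH]1`: 36100 nM

Both compounds share the same core and differ only in what sits on the phenyl ring of the ketone. In a functional assay on HT-29 cells (Homo sapiens) for inhibition, read by WST assay, with a stated time of 48 h (on this read-out higher numbers stand for weaker inhibition and lower numbers for stronger inhibition), compound 1 gives 19200 nM, while compound 2 gives 36100 nM. Among the measured compounds shown here, of the two numbers, the one for compound 2 stands at the top, but its gap to compound 1 lies within the usual scatter of repeated measurement, so the two compounds cannot be told apart on these data.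

Compound 3, `O=C(CSc1nc2ccccc2[nH]1)c1ccccc1`, has not yet been measured. It differs from compound 2 in one place: hydrogen in place of methoxy on an aromatic carbon. For the measured compounds named here, nothing measured so far isolates the effect of this methoxy group, so the only guide is that the two known compounds, with different substituents on that ring, sit close together. On that basis the step from compound 2 to compound 3 is expected to be small, a 1.3-fold lower number from compound 2 to compound 3 (0.11 log units; within the scatter), and not beyond the scatter in either direction. Compound 3 is therefore estimated at 28000 nM, with a plausible range from 10000 nM to 75000 nM.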

Compound 3, half-maximal inhibitory concentration: 38500 nM
Beside the measured number, compound 3's estimate is 1.4-fold (0.14 log units) below it; the range from low to high includes it.
By their numbers in this assay, from the lowest: compounds 1, 2 and 3 (each within the scatter of the next).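

Among the compounds shown here, compound 3 gives the first direct reading of a single group on this ring. In this assay, hydrogen in place of methoxy on an aromatic carbon, ortho to a large group, gives a 1.1-fold higher number from compound 2 to compound 3 (0.03 log units; within the scatter), so removing the methoxy group leaves a pair that cannot be told apart. Hydrogen in place of hydroxy on an aromatic carbon gives a 2.0-fold higher number from compound 1 to compound 3 (0.30 log units; within the scatter), which also lies within the scatter, so on this read-out neither group is shown to matter, and no other measurement is available to explain the result.

The compounds shown say nothing about an amine, a carboxylic acid or a chlorine atom on this ring, or about a longer chain in place of methoxy. Going by these compounds, whether any such group would carry the number beyond the scatter, in either direction, remains open, as does the contribution of the shared core, which is the same in all three compounds.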